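The compounds below may be only part of what the source reports. "The series", "measured", "known", "first", "only" and "open" are said of these compounds alone.

Of the compounds shown here, two that share one core have been measured so far. Compound 1 `COc1ccc2[nH]c(C(=O)N3CC(=O)N(Cc4ccoc4)[C@@H](Cc4ccccc4)C3)cc2c1` in a physicochemical assay for solubility, read by spectrophotometry, in phosphate buffer, with a stated time of 2 h, at pH 7.4 (a lower number here means a less soluble compound, a higher number a more soluble compound), gives 63600 nM. Compound 2 `COc1ccc2[nH]c(C(=O)N3CC(=O)N(Cc4ccc[nH]4)[C@@H](Cc4ccccc4)C3)cc2c1` in this assay gives 38400 nM. Among the compounds with values here, the one step between them, a 1.7-fold lower number from compound 1 to compound 2 (0.22 log units; within the scatter), swapped one five-membered aromatic ring for another on the chain carbon bound to the ring nitrogen. Compound 2 therefore stands alongside compound 1, the two numbers being within the scatter of one another.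

Compound 3 `COc1ccc2[nH]c(C(=O)N3CC(=O)N(c4ccccc4)[C@@H](Cc4ccccc4)C3)cc2c1` differs from compound 2 in one place: phenyl in place of (1H-pyrrol-2-yl)methyl on an amide-type nitrogen in a ring. Within the data shown here, no measured step removes the saturated chain carbon or places a ring directly on that nitrogen, so the only step that bears on this change, from compound 1 to compound 2, is an indirect one, and it was within the scatter. Among the measured compounds shown here, the loss of the hydrogen-bond donor is the part of the change that no measured pair covers. Compound 3 is expected to come out somewhat lower, by a 1.6-fold lower number from compound 2 to compound 3 (0.20 log units; within the scatter). The estimate for compound 3 in this assay is 24000 nM, with a range from 8000 nM to 70000 nM.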

Compound 3, solubility: 36100 nM
For compound 3 the middle estimate is 1.5-fold (0.18 log units) below the measured one, within the range that was stated.
By their numbers in this assay, from the lowest: compounds 3, 2 and 1 (each within the scatter of the next).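

The earlier step only exchanged one five-membered aromatic ring for another with the saturated chain carbon kept, whereas this change on the amide-type nitrogen in a ring also removes that chain carbon and brings in a six-membered aromatic ring of carbon only. In this assay, both a 1.1-fold lower number from compound 2 to compound 3 (0.03 log units; within the scatter) and a 1.8-fold lower number from compound 1 to compound 3 (0.25 log units; within the scatter) stay within the scatter, so the numbers for this position do not separate, even though the change from compound 2 to compound 3 also takes the count of hydrogen-bond donors in the group from 1 to 0. Nothing available explains why these numbers stay together.

Because phenyl differs from the (1H-pyrrol-2-yl)methyl group in both its ring and its chain carbon, the compounds shown cannot say whether either change alone would move the number, and benzyl on this nitrogen would bear on that question. They also leave open how this assay would respond to a very different group at the same nitrogen, such as an amine or a carboxylic acid carried on a longer chain.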